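Antiproliferative series: amide substituent variation on compound 1

The source may report more compounds than this note shows. Statements on the series, on what has been measured and on what is new or still open speak of the compounds shown alone.

Measured compounds:
compound 1 `CCn1c(C(=O)NCCCN(C)C)ccc1C(CC)(CC)c1ccc(OCCC(O)(CC)CC)c(C)c1` — 490 nM
compound 2 `CCn1c(C(=O)NCCN)ccc1C(CC)(CC)c1ccc(OCCC(O)(CC)CC)c(C)c1` — 1740 nM

Compound 1 has the lowest number of the two in a functional assay on Caco-2 cells (Homo sapiens) for antiproliferative activity, read by MTT assay, with a stated time of 48 h; a higher number here means a weaker inhibitor, a lower number a stronger inhibitor. Among the compounds with values here, the one measured step, a 3.6-fold higher number from compound 1 to compound 2 (0.55 log units; beyond the scatter), changes the amide substituent, but in a different way from the change to compound 3 `CCOc1ccc(NC(=O)c2ccc(C(CC)(CC)c3ccc(OCCC(O)(CC)CC)c(C)c3)n2CC)cc1`. That change is 4-ethoxyphenyl in place of 3-(dimethylamino)propyl on an amide-type nitrogen. Within the data shown here, the only step so far shows that altering this amide substituent can shift the read-out beyond the scatter, yet no measured compound carries an aromatic group there, so the direction for compound 3 cannot be read from the data. A step from compound 1 of uncertain direction, at most modest, is therefore expected, with a wide range; the estimate is a 1.8-fold higher number from compound 1 to compound 3 (0.26 log units; within the scatter). Compound 3 is estimated at 900 nM, expected between 200 nM and 4000 nM.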

Compound 3, half-maximal inhibitory concentration: > 50000 nM
Compound 3 ended at the assay's limit (the forecaster's own chance of this, stated with the estimate: 10%); middle value at least 55-fold (1.74 log units) away from the limit.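

In this assay compound 3 reads > 50000 nM, which is a limit of the assay and not a number. On the amide-type nitrogen, 4-ethoxyphenyl in place of 3-(dimethylamino)propyl gives an at least 100-fold higher number from compound 1 to compound 3 (2.00 log units; beyond the scatter), and 4-ethoxyphenyl in place of 2-aminoethyl gives an at least 28-fold higher number from compound 2 to compound 3 (1.45 log units; beyond the scatter). The earlier change between the two amine-bearing chains gave only a 3.6-fold higher number from compound 1 to compound 2 (0.55 log units; beyond the scatter), so this position is now shown to allow a large loss of antiproliferative activity, not just a modest shift.

The compounds shown leave open whether the loss follows the aromatic ring, the ethoxy group or the loss of the amine from the substituent. A plain phenyl, a benzyl group or a 4-(dimethylamino)phenyl group on the same nitrogen would separate these readings.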